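A few compounds are considered here, and "the series" means these few. Any claim that something is new, unique, unknown or untested is made for them only; others in the source may bear on it.

In a functional assay on A549 cells (Homo sapiens) for cytotoxicity, read by sulforhodamine B assay, with a stated time of 3 days (on this read-out higher numbers stand for an effect only at larger amounts of compound and lower numbers for an effect already at smaller amounts), compound 1 (`CCOCc1c(C)coc1-c1ccc2c(c1OC)CCCC2(C)C`) gives 22.9 uM and holds the lower of the two numbers, beyond the scatter from compound 2 (`Cc1coc(-c2ccc3c(c2O)CCCC3)c1C(=O)O`), which gives 57 uM on the same scale. Compound 3 (`COC(=O)c1c(C)coc1-c1ccc2c(c1OC)CCCC2(C)C`) keeps the core of compound 1 but has methoxycarbonyl in place of ethoxymethyl on an aromatic carbon. Among the compounds with values here, no measured pair shows this change, so only a modest move towards a higher number is expected, and the estimated step (a 1.4-fold higher number from compound 1 to compound 3 (0.15 log units; within the scatter)) may stay close to the scatter. Compound 3 is expected at 32 uM with an estimated range (13 uM to 75 uM).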

Compound 3, concentration for half-maximal effect: 61 uM
Estimate against measurement, compound 3: 1.9-fold (0.28 log units) below; the measured number falls inside the stated range.
By their numbers in this assay, from the lowest: compound 1; then compounds 2 and 3 (each within the scatter of the next).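

Methoxycarbonyl in place of ethoxymethyl on this aromatic carbon gives the only direct reading at this position: in this assay the change brings a 2.7-fold higher number from compound 1 to compound 3 (0.43 log units; beyond the scatter) and so moves the number to the higher side. The position is therefore not indifferent to what it carries, even though both groups have 4 heavy atoms. Nothing at hand explains this shift.

The compounds shown leave open whether an amine or a longer chain on this carbon would give a lower or a higher number than ethoxymethyl. They also leave open whether the same change would have a similar effect on another core.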